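The source may report more compounds than this note shows. Statements on the series, on what has been measured and on what is new or still open speak of the compounds shown alone.

Values in a functional assay on MDA-MB-435 cells (Homo sapiens) for antiproliferative activity, read by CellTiter-Glo, with a stated time of 96 h; on this read-out lower numbers stand for stronger inhibition and higher numbers for weaker inhibition:

- compound 1 `COc1ccc(-c2nsc3c2NC(=O)CC3c2cccc(OC)c2)cc1` gives 591 nM
- compound 2 `COc1ccc(-c2nsc3c2NC(=O)CC3c2cccc(F)c2)cc1` gives 1410 nM
- compound 3 `COc1ccc(-c2nsc3c2NC(=O)CC3c2ccc(F)cc2)cc1` gives 1820 nM

Compound 3 cannot be separated from compound 2 (a 1.3-fold higher number from compound 2 to compound 3 (0.11 log units; within the scatter)), and it stands clearly apart from compound 1 (a 3.1-fold higher number from compound 1 to compound 3 (0.49 log units; beyond the scatter)).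

The next change leads to compound 4 `COc1ccc(-c2nsc3c2NC(=O)CC3c2ccsc2)cc1` and is thiophen-3-yl in place of 4-fluorophenyl on a saturated ring carbon. Thiophen-3-yl thus takes the place of 4-fluorophenyl on the saturated ring carbon, three ring bonds from the ring nitrogen.

For the measured compounds named here, no measured compound carries a five-membered aromatic ring at this carbon, so the available steps bear on it only indirectly. Two of them are exchanges at the same carbon, and they stay small: one is within the scatter (a 1.3-fold higher number from compound 2 to compound 3 (0.11 log units; within the scatter)) and the other modest (a 3.1-fold higher number from compound 1 to compound 3 (0.49 log units; beyond the scatter)). The step on the aromatic substituent is also modest (a 2.4-fold higher number from compound 1 to compound 2 (0.38 log units; beyond the scatter)).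

A step in this assay no larger than these is therefore expected, most likely within the scatter. The direction is uncertain, with a slight lean towards a lower number, as compound 4 lacks fluorine, as does compound 1 (591 nM).

The expected change is a 1.5-fold lower number from compound 3 to compound 4 (0.18 log units; within the scatter).

For compound 4 the estimate is 1200 nM, with an expected range from 500 nM to 2800 nM.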

Compound 4, half-maximal inhibitory concentration: 80.7 nM
Compound 4: the middle estimate sits 15-fold (1.17 log units) above what was measured; the measured number lies below the stated range.
By their numbers in this assay, from the lowest: compound 4; then compound 1; then compounds 2 and 3 (each within the scatter of the next).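

In this assay, the saturated ring carbon three ring bonds from the ring nitrogen proves far more responsive than the exchanges among substituted phenyl groups had indicated: thiophen-3-yl brings a 23-fold lower number from compound 3 to compound 4 (1.35 log units; beyond the scatter) and a 17-fold lower number from compound 2 to compound 4 (1.24 log units; beyond the scatter), both large, whereas a 1.3-fold higher number from compound 2 to compound 3 (0.11 log units; within the scatter) separated the two fluorophenyl compounds by no more than the scatter. The step from the lowest of the earlier numbers is smaller but still clear, a 7.3-fold lower number from compound 1 to compound 4 (0.86 log units; beyond the scatter), so compound 4 stands beyond the scatter from all three phenyl compounds and a five-membered aromatic ring with a sulfur atom is the best group shown at this carbon. Nothing available accounts for this gain, so the roles of the smaller ring, the sulfur atom and the loss of the phenyl substituent remain unassigned.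

The compounds shown leave open whether the gain is specific to thiophen-3-yl, a question that thiophen-2-yl, furan-3-yl and unsubstituted phenyl at this carbon would address. They also leave open whether an aromatic ring is needed here at all, as cyclopentyl or an aminomethyl group would show.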